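A few compounds are considered here, and "the series" means these few. Any claim that something is new, unique, unknown or untested is made for them only; others in the source may bear on it.

Compound 2 `O=C1C(Nc2ccccc2)=CC(=O)c2c1nc1n2[C@H]2OC[C@@H](O)[C@H]2OC1` and compound 1 `CCCc1ccc(NC2=CC(=O)c3nc4n(c3C2=O)[C@H]2OC[C@@H](O)[C@H]2OC4)cc1` share one core and one anilino group. In a functional assay on MGC-803 cells (Homo sapiens) for inhibition, read by sulforhodamine B assay (a higher number here means a weaker inhibitor, a lower number a stronger inhibitor), compound 2 gives 1830 nM, the higher of the two numbers seen, while compound 1 gives 1560 nM, a gap that lies within the usual scatter. Compound 3 `CCCN(CCC)C1=CC(=O)c2nc3n(c2C1=O)[C@H]1OC[C@@H](O)[C@H]1OC3` reaches only a limit of this assay, > 16000 nM, and no number.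

Compound 4 `CCOc1ccc(NC2=CC(=O)c3c(nc4n3[C@H]3OC[C@@H](O)[C@H]3OC4)C2=O)cc1` has not been measured. It differs from compound 2 by ethoxy in place of hydrogen on an aromatic carbon. Compound 1, which also carries a group para to a large group, sits within the scatter of compound 2, and compound 1 gives 1560 nM. In this assay the author therefore expects no step beyond the scatter, with the expected change being a 1.1-fold lower number from compound 2 to compound 4 (0.06 log units; within the scatter). Compound 4 is therefore estimated at 1600 nM, with a range from 600 nM to 4500 nM.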

Compound 4, half-maximal inhibitory concentration: 2090 nM
Estimate against measurement, compound 4: 1.3-fold (0.12 log units) below, within the range that was stated.
By their numbers in this assay, from the lowest: compounds 1, 2 and 4 (each within the scatter of the next). At a limit, above all of these: compound 3.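

Replacing phenyl with 4-ethoxyphenyl gives a 1.1-fold higher number from compound 2 to compound 4 (0.06 log units; within the scatter) in this assay. This single-place comparison shows that ethoxy can stand on this aromatic carbon, para to a large group, with no step beyond the scatter. Nothing shown gives a cause for this result. On these data alone, whether an amine or a carboxylic acid on the same carbon would also stay within the scatter remains open. So does whether ethoxy would behave alike on another carbon of this ring.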